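Dimethoxyphenyl Sulfone Weighed Against Three Halogenated Analogues

A few compounds are considered here, and "the series" means these few. Any claim that something is new, unique, unknown or untested is made for them only; others in the source may bear on it.

Of the compounds shown here, three sharing one core have been measured in an assay on isolated protein for displacement of a labelled ligand from metabotropic glutamate receptor 5 (Homo sapiens), with a stated time of 60 min, tested at 1 uM; a higher number here means more inhibition at the concentration tested (going by the name of the read-out), a lower number less inhibition. Compound 1 `Cc1ccc(S(=O)(=O)c2cnc3ccc(Cl)cc3c2N2CCC(C)CC2)cc1F` gives 68%, compound 2 `CC1CCN(c2c(S(=O)(=O)c3cccc(Cl)c3)cnc3ccc(Cl)cc23)CC1` gives 92%, and compound 3 `Cc1ccc(S(=O)(=O)c2cnc3ccc(Cl)cc3c2N2CCC(C)CC2)cc1Cl` gives 81%. Compound 3 stands second highest of the three numbers: the read-out is a number 11 percentage points lower from compound 2 to compound 3 (beyond the scatter), while it is a number 13 percentage points higher from compound 1 to compound 3 (beyond the scatter).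

Compound 4 `COc1ccc(S(=O)(=O)c2cnc3ccc(Cl)cc3c2N2CCC(C)CC2)cc1OC` has not yet been measured in this assay. It differs from compound 3 in one place: 3,4-dimethoxyphenyl in place of 3-chloro-4-methylphenyl on a sulfonyl sulfur.

Among the compounds with values here, two measured steps bear on this change. Both alter the aryl group on the sulfonyl sulfur. Replacing the whole ring gave a read-out a number 24 percentage points higher from compound 1 to compound 2 (beyond the scatter), and exchanging a single substituent on that ring gave a number 13 percentage points higher from compound 1 to compound 3 (beyond the scatter). Within the data shown here, both steps were modest and both stayed among halogenated rings, whereas the 3,4-dimethoxyphenyl ring of compound 4 carries two hydrogen-bond acceptors and no halogen, so no measured step covers it directly. Among the measured compounds shown here, since every variation so far moved the number by a modest amount, and the ring now leaves the pattern of the three measured compounds, a modest fall is expected, with wide uncertainty.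

Compound 4 is therefore estimated to give 55% in this assay, within a range from 25% to 80%. This estimate means an expected step of a number 26 percentage points lower from compound 3 to compound 4 (beyond the scatter).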

Compound 4, a percentage reported as inhibition, at one concentration (the size of the read-out at that concentration, not a potency): 61%
Beside the measured number, compound 4's estimate is 6 percentage points below it; low and high end bracket the measured number.
By their numbers in this assay, from the lowest: compounds 4 and 1 (each within the scatter of the next); then compound 3; then compound 2.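

In this assay, within the data shown here, the position on the sulfonyl sulfur also takes a ring with no halogen, and the change to 3,4-dimethoxyphenyl gives a number 20 percentage points lower from compound 3 to compound 4 (beyond the scatter) and then a number 31 percentage points lower from compound 2 to compound 4 (beyond the scatter) when set against the 3-chlorophenyl ring, the only step at this position so far that counts as large. Against the 3-fluoro-4-methylphenyl ring the same change gives a number 7 percentage points lower from compound 1 to compound 4 (within the scatter) and so cannot be told apart, which shows that a ring with two hydrogen-bond acceptors and no halogen can read the same as a halogenated one, while the chlorinated rings of compound 2 and compound 3 stand clear of it. Nothing available explains why these rings differ.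

The compounds shown leave open whether one methoxy group alone would read like the pair, and how a ring bearing an amine or a carboxylic acid on the sulfonyl sulfur would behave. Since every number is a percentage at a single concentration, they also leave open how far these compounds differ in potency.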